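This account rests on a few compounds, and the source may have more. Where it says the series, first, only, none or still open, it means among the compounds named here.

Compound 1 `Cn1c(CN2CCN(c3ccc(C(F)(F)F)cn3)CC2)nc2ccccc21` is assessed in an assay on CHO cells with metabotropic glutamate receptor 2 (Homo sapiens) as the target, read by FLIPR (on this read-out lower numbers stand for an effect already at smaller amounts and higher numbers for an effect only at larger amounts of compound), where compound 1 gives 501 nM. Among the three measured compounds it holds the second highest number: compound 3 `Cn1c(CN2CCC(c3cccc(C(F)(F)F)c3)CC2)nc2ccccc21` gives 100 nM, while compound 2 `Cn1c(CN2CCN(c3ccccn3)CC2)nc2ccccc21` gives 15800 nM. Among the measured compounds shown here, the only measured step on the shared core, a 32-fold higher number from compound 1 to compound 2 (1.50 log units; beyond the scatter), shows how much the loss of the trifluoromethyl costs. Compound 4 `Cn1c(CN2CCN(c3ncc(C(F)(F)F)cc3Cl)CC2)nc2ccccc21` keeps that group and differs from compound 1 by chloro in place of hydrogen on an aromatic carbon. For the measured compounds named here, no measured step adds a halogen at such a place, so the size of this step in this assay remains uncertain; a moderate change toward a lower number is expected. Compound 4 is estimated at 250 nM, within 80 nM to 800 nM, corresponding to a 2.0-fold lower number from compound 1 to compound 4 (0.30 log units; within the scatter).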

Compound 4, half-maximal effective concentration: 79.4 nM
Compound 4: the middle estimate sits 3.1-fold (0.50 log units) above what was measured; measured number outside the range, below it.
By their numbers in this assay, from the lowest: compounds 4 and 3 (each within the scatter of the next); then compound 1; then compound 2.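

Among the compounds shown here, compound 4 gives the first measured change at this aromatic carbon, ortho to a large group and two atoms from the ring nitrogen: with the trifluoromethyl group kept, chloro in place of hydrogen brings a 6.3-fold lower number from compound 1 to compound 4 (0.80 log units; beyond the scatter), so this place takes a halogen and the number falls beyond the scatter. Nothing at hand gives a cause for this step.

As far as these compounds go, whether the step is particular to chloro stays open, since fluoro, methyl, methoxy or a nitrile at this carbon could differ. From the compounds shown here alone, it is also open whether chloro brings a similar step on compound 2, without the trifluoromethyl group.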